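This account rests on a few compounds, and the source may have more. Where it says the series, first, only, none or still open, it means among the compounds named here.

Measured so far in a functional assay on RCC4 cells (Homo sapiens) for inhibition, read by XTT assay, with a stated time of 4 days; a lower number here means a stronger inhibitor, a higher number a weaker inhibitor:
- compound 1, `Fc1cccc(Nc2nc(-c3ccncc3)cs2)c1`: 40700 nM
- compound 2, `CC(=O)c1ccc(-c2cc(-c3csc(Nc4cccc(C)c4)n3)ccn2)cc1`: 38800 nM; 38900 nM (2 entries)
- compound 3, `Cc1cccc(Nc2nc(-c3ccnc(N4CCN(C)CC4)c3)cs2)c1`: 11500 nM; 11700 nM (2 entries)

For the measured compounds named here, compound 1 carries the one value shown for it; two further entries for compound 1 in this assay give no single number. Compound 2 was run more than once and its entries agree closely (the several entries of compound 2 in this assay, 38800 nM; 38900 nM (2 entries)), as do the entries of compound 3 (the several entries of compound 3 in this assay, 11500 nM; 11700 nM (2 entries)). Going by the values given here, compound 1 and compound 2 sit within the usual scatter of each other, whereas compound 3 gives the lowest value of the three; no single-point step connects compound 1 to either of them, so their values are only placed side by side here.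

Compound 4, `Brc1cccc(Nc2nc(-c3ccncc3)cs2)c1`, has not yet been measured. It differs from compound 1 by one change: bromo in place of fluoro on an aromatic carbon. No measured pair in the series shows an exchange of one halogen for another, so the direction rests on no shown step. A modest move is expected, a 1.9-fold lower number from compound 1 to compound 4 (0.27 log units; within the scatter), with the odds slightly towards a lower number. Compound 4 is therefore estimated at 22000 nM, between 7000 nM and 65000 nM.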

Compound 4, half-maximal inhibitory concentration: 40700 nM
Compound 4: middle estimate off by 1.9-fold (0.27 log units), on the low side, and the stated range covers the measured number.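

In this assay, for the compounds shown here, bromo in place of fluoro on an aromatic carbon, meta to a large group, gives the first single-place step, and it shows no change at the digits printed from compound 1 to compound 4 (within the scatter). At this position, then, the exchange of one halogen for the other, with no ring, donor, acceptor or net charge entering or leaving, leaves the reading unmoved. The identical printed values can be taken at face value as far as repeat agreement elsewhere in the series allows, since repeated entries in this assay lie close together: the several entries of compound 2 in this assay, 38800 nM; 38900 nM (2 entries)

On these data alone, whether a group other than a halogen at this position, such as an amine, a methoxy group or a carboxylic acid, would move the number remains open. Going by these compounds alone, no single-place step yet connects compound 4 to compound 2 or compound 3, so their values cannot be tied to any one change.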